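Capping a free hydroxy group with methyl

The source may hold more compounds than are shown below. What is called first, only, known or untested is meant among the compounds shown, and "the series" means these compounds.

Measured in a functional assay on HCT-116 cells (Homo sapiens) for antiproliferative activity, read by MTT assay, with a stated time of 72 h (a lower number here means a stronger inhibitor, a higher number a weaker inhibitor), are these two compounds:
Compound 1 `COc1cc(/C=C/C(=O)/C=C(O)/C=C/c2ccc(OC(=O)C(C)(CO)CO)c(OC)c2)ccc1OC(=O)C(C)(CO)CO` gives 3910 nM
Compound 2 `COc1cc(/C=C/C(O)=C/C(=O)/C=C/c2ccc(OC(=O)C(C)(CO)CO)c(OC)c2)ccc1O` gives 15500 nM

Compound 2 has the higher of the two numbers, which makes it the weaker inhibitor of the pair. Compound 3 `COc1ccc(/C=C/C(O)=C/C(=O)/C=C/c2ccc(OC(=O)C(C)(CO)CO)c(OC)c2)cc1OC` differs from compound 2 in one group. The change is methyl in place of hydrogen on an oxygen on an aromatic ring and it places methyl in place of hydrogen on an oxygen on an aromatic ring, so 4-hydroxy-3-methoxyphenyl becomes 3,4-dimethoxyphenyl.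

The step of a 4.0-fold higher number from compound 1 to compound 2 (0.60 log units; beyond the scatter) is the only measured one that bears on this. It is modest but beyond the scatter, and it also changes what sits on an oxygen on an aromatic ring. In that single pair, the compound with the free hydroxy has the higher number. Methyl is a much smaller group than the one lost in that step, so only a part of that step is expected to carry over, towards a lower number. In this assay the estimate is therefore a 1.6-fold lower number from compound 2 to compound 3 (0.19 log units; within the scatter) and this small expected step may stay within the scatter. The estimated value of compound 3 is 10000 nM and the expected range runs from 4500 nM up to 22000 nM at its upper end.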

Compound 3, half-maximal inhibitory concentration: 4770 nM
The estimate for compound 3 lay 2.1-fold (0.32 log units) above the measured number; measured number inside the range.
By their numbers in this assay, from the lowest: compounds 1 and 3 (each within the scatter of the next); then compound 2.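

Measured in this assay, replacing the free hydroxy with methoxy gives a 3.2-fold lower number from compound 2 to compound 3 (0.51 log units; beyond the scatter) and shows that the lower number does not need the large ester group: a cap of one carbon on this oxygen also reaches it. Removing the (1,1-bis(hydroxymethyl)ethyl)carbonyl group gave a 4.0-fold higher number from compound 1 to compound 2 (0.60 log units; beyond the scatter) while exchanging it for methyl gives a 1.2-fold higher number from compound 1 to compound 3 (0.09 log units; within the scatter) so the two caps cannot be told apart in this assay, despite their very different sizes. Among these three compounds, compound 2, the only one with a free hydroxy at this position, has the highest number, and neither of the others goes against this, whereas the single earlier step could only hint at it.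

No supporting measurement is available to explain why a capped oxygen goes with the lower number. Going by these compounds, it also remains open whether a longer chain such as propyl or a small acyl group such as acetyl on this oxygen would fit the same pattern, or how an amine in place of the oxygen would behave.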